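This account rests on a few compounds, and the source may have more. Where it says the series, first, only, none or still open, it means among the compounds named here.

Measured so far in an assay on isolated protein for binding affinity to secreted frizzled-related protein 1 (Homo sapiens), read by fluorescence; a lower number here means a stronger inhibitor, a higher number a weaker inhibitor:
Compound 1 `O=C(CN1CCCC1)N1CCC(NS(=O)(=O)c2cc(S(=O)(=O)c3ccccc3)ccc2C(F)(F)F)CC1`: 110 nM
Compound 2 `CC(C)(C)C(=O)N1CCC[C@H]1C(=O)N1CCC(NS(=O)(=O)c2cc(S(=O)(=O)c3ccccc3)ccc2C(F)(F)F)CC1`: 40 nM

Going by the values given here, compound 2 stands at the lowest of the two numbers; the single measured step, a 2.8-fold lower number from compound 1 to compound 2 (0.44 log units; beyond the scatter), separates it from compound 1. Compound 3 `O=C([C@@H]1CCCN1C(=O)c1ccncc1)N1CCC(NS(=O)(=O)c2cc(S(=O)(=O)c3ccccc3)ccc2C(F)(F)F)CC1` differs from compound 2 by pyridin-4-yl in place of tert-butyl on a carbonyl carbon. Among the compounds with values here, no measured step touches this acyl group, so the one step on record bears only indirectly and gives no direction. A step within the scatter, or at most a small one either way, is expected. Compound 3 is estimated at 50 nM (range 15 nM to 160 nM), which means an expected step of a 1.3-fold higher number from compound 2 to compound 3 (0.10 log units; within the scatter).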

Compound 3, half-maximal inhibitory concentration: 70 nM
The estimate for compound 3 lay 1.4-fold (0.15 log units) below the measured number; the measured number falls inside the stated range.
By their numbers in this assay, from the lowest: compounds 2, 3 and 1 (each within the scatter of the next, the first and the last beyond it).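

In this assay, pyridin-4-yl in place of tert-butyl on a carbonyl carbon gives a 1.8-fold higher number from compound 2 to compound 3 (0.24 log units; within the scatter), so at this position a six-membered aromatic ring carrying a hydrogen-bond acceptor replaces a branched group without a step beyond the scatter. Going by these compounds alone, this is the first measured change at this acyl group. No supporting evidence bears on the reason for this result.

Open, as far as these compounds go, is whether pyridin-3-yl, phenyl or a smaller acetyl group on this carbonyl carbon stays within the scatter of compound 2. Also open, from the compounds shown here alone, is how an amine or a carboxylic acid on the acyl group would read.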